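This account rests on a few compounds, and the source may have more. Where it says the series, first, only, none or still open, it means among the compounds named here.

Compound 1 `CN(C)c1ccc(NCc2cncn2Cc2ccc(-c3ccccc3)cc2)cc1-c1ccccc1` is one of three compounds tested in a toxicity assay on NIH3T3 cells (Mus musculus) for cytotoxicity, read by resazurin assay; on this read-out higher numbers stand for an effect only at larger amounts of compound and lower numbers for an effect already at smaller amounts. In this assay compound 1 gives > 1000 nM, which is a limit of the assay and not a measured number. Compound 2 `CC(C)c1ccc(Cn2cncc2CNc2ccc(-c3nc4ccccc4s3)c(-c3ccccc3)c2)cc1` gives > 1000 nM in this assay, likewise a limit. Compound 3 `Cc1ccccc1-c1cccc(NCc2cncn2Cc2ccccc2)c1` gives > 1000 nM in this assay, again a limit. All three values therefore sit at the same place: the limit of > 1000 nM in this assay, at which 3 of the 3 values shown sit. Among the compounds with values here, no step between two measured compounds can be read from them, and nothing tells where within the region past the limit any of the three lies.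

Compound 4 `CCCC(=O)c1ccc(NCc2cncn2Cc2ccc(-c3ccccc3)cc2)cc1-c1ccccc1` differs from compound 1 in one place: propylcarbonyl in place of dimethylamino on an aromatic carbon. Within the data shown here, no measured step shows how a change of this kind moves the read-out. The expectation is that the step that the limit leaves unreadable from compound 1 to compound 4 is none beyond the scatter, because all three measured values rest at the limit of > 1000 nM in this assay, at which 3 of the 3 values shown sit. Compound 4 is therefore estimated at 3000 nM in this assay, with a range from 1000 nM to 20000 nM, and most likely it too will be reported only as a limit.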

Compound 4, half-maximal effective concentration: > 10000 nM
Compound 4: a limit, no number; the forecaster's own chance of this, stated with the estimate: 85%; middle value at least 3.3-fold (0.52 log units) from the limit.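

Within the data shown here, compound 1 and compound 4 are each reported only as a limit in this assay, so no step between them can be read. The compounds shown leave open whether putting propylcarbonyl in place of dimethylamino moves the read-out at all.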